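The compounds below may be only part of what the source reports. "The series", "measured", "known", "first", "only" and "open" are said of these compounds alone.

Compound 1 `CCCc1ccc(N2C(=O)NC3(CSC4=C3C(=O)c3ncccc3C4=O)C2=O)cc1` gives 450 nM in a functional assay on XF498 cells (Homo sapiens) for antiproliferative activity, read by MTT assay, with a stated time of 96 h (a lower number here means a stronger inhibitor, a higher number a weaker inhibitor), the lowest of the three measured numbers. Within the data shown here, compound 2 `O=C1NN(c2ccc(Cl)cc2)C(=O)C2(CSC3=C2C(=O)c2ncccc2C3=O)N1` gives 2500 nM in this assay, and compound 3 `Cc1ccc(N2NC(=O)NC3(CSC4=C3C(=O)c3ncccc3C4=O)C2=O)cc1` gives 3800 nM in this assay; the only single-point step measured, a 1.5-fold higher number from compound 2 to compound 3 (0.18 log units; within the scatter), lies within the scatter. Compound 4 `CC(C)(C)c1ccc(N2C(=O)NC3(CSC4=C3C(=O)c3ncccc3C4=O)C2=O)cc1` differs from compound 1 in one place: tert-butyl in place of propyl on an aromatic carbon, taking 4-propylphenyl to 4-(tert-butyl)phenyl. Among the measured compounds shown here, no measured step covers this change; the step from compound 2 to compound 3 concerns a different pair of groups and gives no direction to carry over. The expectation is therefore a step no larger than the scatter, a 1.1-fold higher number from compound 1 to compound 4 (0.05 log units; within the scatter). Compound 4 is estimated at 500 nM, between 200 nM and 1500 nM in this assay.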

Compound 4, half-maximal inhibitory concentration: 850 nM
Estimate against measurement, compound 4: 1.7-fold (0.23 log units) below, within the range that was stated.
By their numbers in this assay, from the lowest: compounds 1 and 4 (each within the scatter of the next); then compounds 2 and 3 (each within the scatter of the next).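

Replacing propyl with tert-butyl gives a 1.9-fold higher number from compound 1 to compound 4 (0.28 log units; within the scatter) in this assay, so on this aromatic carbon, para to a large group, the two alkyl groups are not told apart. Among these compounds, this is the first step read on the core of compound 1, as the earlier step concerned methyl and chloro on another core. Nothing at hand gives a reason for this result.

Open, going by these compounds, is whether an amine or a carboxylic acid at this position would stay within the scatter of compound 1. Also open, on these data alone, is whether a longer chain, such as octyl, would do so.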